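Smaller substituent on the amine nitrogen: compound 3 to compound 4

A few compounds are considered here, and "the series" means these few. Any claim that something is new, unique, unknown or untested is made for them only; others in the source may bear on it.

Compound 1 `C/N=C(/NC#N)NCCCCCn1nc(-c2ccccc2)ccc1=O` gives 100 mg/kg in a functional assay on the whole organism (stomach) with Rattus norvegicus as the target; a lower number here means that less compound is needed, a higher number that more compound is needed for the effect. Compound 2 `CC(C)(C)/N=C(\S)NCCCCn1nc(-c2ccccc2)ccc1=O` reaches only a limit of this assay, > 100 mg/kg. Compound 3 `C=CCNC(=S)NCCCCn1nc(-c2ccccc2)ccc1=O` likewise sits at a limit, > 100 mg/kg. The steps of a number no lower from compound 1 to compound 2 (the limit leaves the size open) and a number no lower from compound 1 to compound 3 (the limit leaves the size open) thus read as no lower, and a step that the two limits leave unreadable from compound 2 to compound 3 cannot be read, since the limit of > 100 mg/kg in this assay, at which 2 of the 3 values shown sit, covers two of the three values. Compound 4 `C/N=C(\S)NCCCCn1nc(-c2ccccc2)ccc1=O` differs from compound 3 by a group of 4 heavy atoms (2 carbon, 1 nitrogen, 1 sulfur; no ring) in place of a group of 6 heavy atoms (4 carbon, 1 nitrogen, 1 sulfur; no ring), on an amine nitrogen. For the measured compounds named here, no measured step bears directly on this change; the nearest in kind, a step that the two limits leave unreadable from compound 2 to compound 3, is itself unreadable. Compound 4 is therefore expected to remain near the limit, with an estimated step that the limit leaves unreadable from compound 3 to compound 4. The estimate for compound 4 in this assay is 150 mg/kg, in the range 50 mg/kg to 500 mg/kg.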

Compound 4, dose for half-maximal effect: 28.9 mg/kg
Estimate against measurement, compound 4: 5.2-fold (0.72 log units) above, outside the stated range (below it).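

In this assay, for the compounds shown here, methyl gives the first readable change at this position: an at least 3.4-fold lower number from compound 2 to compound 4 (0.53 log units; beyond the scatter) for methyl in place of tert-butyl on a double-bonded nitrogen, and an at least 3.4-fold lower number from compound 3 to compound 4 (0.53 log units; beyond the scatter) for the smaller group on the amine nitrogen. Both sizes are bounds only, because the starting compounds sit at a limit: the limit of > 100 mg/kg in this assay, at which 2 of the 4 values shown sit. Going by these compounds alone, the only step with two numbers behind it is a 3.5-fold lower number from compound 1 to compound 4 (0.54 log units; beyond the scatter), for the smaller group on the saturated chain carbon.

Going by these compounds, whether ethyl or cyclopropyl in place of methyl would hold this number stays open. On these data alone, the full size of both bounded steps also stays open.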